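The compounds below may be only part of what the source reports. "The series", "measured", "known", "first", "only" and "open" are said of these compounds alone.

Of the compounds shown here, two sharing one core have been measured in an assay on CHO cells for displacement of a labelled ligand from adenosine receptor A1 (Homo sapiens), read by scintillation counting, tested at 10 uM; on this read-out higher numbers stand for more inhibition at the one concentration tested (going by the name of the read-out) and lower numbers for less inhibition. Compound 1 `CC(C)(C)Cc1c(-c2cc(F)ccc2F)sc(N)c1C(=O)c1ccc(Cl)cc1` gives 3% in this assay. Compound 2 `CC(C)(C)Cc1csc(N)c1C(=O)c1cccc(C(F)(F)F)c1` gives 1% in this assay. These two numbers lie within the usual scatter of each other, so compound 1 cannot be set apart from compound 2: both show almost no displacement of the labelled ligand at the concentration tested. For the measured compounds named here, no pair of measured compounds differs in a single place, so the effect of any single structural change on this assay is not known from these data. Compound 3 `CC(C)(C)Cc1c(-c2ccsc2)sc(N)c1C(=O)c1ccc(Cl)cc1` differs from compound 1 in one place: thiophen-3-yl in place of 2,5-difluorophenyl on an aromatic carbon. Because compound 1 gives 3% and compound 2 gives 1%, both near zero, the expected step is a number 1 percentage points higher from compound 1 to compound 3 (within the scatter), which stays within the scatter and points in no direction. Compound 3 is therefore estimated to give 4% in this assay, within a range from -6% to 14%.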

Compound 3, a percentage reported as inhibition, at one concentration (the size of the read-out at that concentration, not a potency): 2%
Compound 3: the middle estimate sits 2 percentage points above what was measured; the measured number falls inside the stated range.
By their numbers in this assay, from the lowest: compounds 2, 3 and 1 (each within the scatter of the next).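

In this assay, for the compounds shown here, the first comparison of two compounds differing in one place is now available: putting thiophen-3-yl in place of 2,5-difluorophenyl on the aromatic carbon next to the ring sulfur gives a number 1 percentage points lower from compound 1 to compound 3 (within the scatter). This change swaps a six-membered aromatic ring of carbon only for a five-membered one with a sulfur atom, yet the two compounds cannot be told apart, and both stay close to zero at the one concentration tested. No measurement shown here offers a reason for this result.

Going by these compounds, whether any group on this carbon can raise the number remains open, as the two groups compared here are both aromatic rings; a carboxylic acid, an amine or a longer chain could be placed there. The effect of changing the neopentyl or amino group on the shared core is also unknown.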